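Heteroaryl swap on a sulfonamide nitrogen of a coumarin enaminone

This account rests on a few compounds, and the source may have more. Where it says the series, first, only, none or still open, it means among the compounds named here.

Measured so far:
- compound 1 `CN(C)/C=C/C(=O)c1cc2ccccc2oc1=O` — 147000 nM
- compound 2 `N=C(N)NS(=O)(=O)c1ccc(N/C=C\C(=O)c2cc3ccccc3oc2=O)cc1` — 87600 nM
- compound 3 `Cc1cc(NS(=O)(=O)c2ccc(N/C=C\C(=O)c3cc4ccccc4oc3=O)cc2)on1` — 75600 nM

All three share one core, a coumarin carrying an enaminone arm, and differ only in what hangs on the nitrogen of that arm. In a functional assay on T47D cells (Homo sapiens) for cytotoxicity, read by sulforhodamine B assay, with a stated time of 48 h (on this read-out higher numbers stand for weaker inhibition and lower numbers for stronger inhibition), compound 1, with a simple dimethylamino group, gives 147000 nM. Compound 2 carries an aminobenzenesulfonamide ending in a guanidine-like group and gives 87600 nM. Compound 3 replaces that group with a methylisoxazole and gives 75600 nM. Its number is the smallest of the three, but the step of a 1.2-fold lower number from compound 2 to compound 3 (0.06 log units; within the scatter) is within the scatter, and its gap to compound 1 is likewise within the scatter, so no real ordering can be claimed.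

Compound 4 `Cc1nnc(NS(=O)(=O)c2ccc(N/C=C\C(=O)c3cc4ccccc4oc3=O)cc2)s1` continues this series: 5-methyl-1,3,4-thiadiazol-2-yl in place of 3-methyl-1,2-oxazol-5-yl on a sulfonamide nitrogen. Going by the values given here, the only measured step at this position is a 1.2-fold lower number from compound 2 to compound 3 (0.06 log units; within the scatter), which barely moved the number even though it exchanged a chain for a ring. A ring-for-ring exchange at the same place is therefore expected to move the number no further than the scatter, with no clear direction, so a 1.1-fold lower number from compound 3 to compound 4 (0.03 log units; within the scatter) is the estimated step. Compound 4 is thus estimated at 70000 nM, with a likely range from 35000 nM to 150000 nM.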

Compound 4, half-maximal inhibitory concentration: 94000 nM
Estimate against measurement, compound 4: 1.3-fold (0.13 log units) below; the measured number falls inside the stated range.
By their numbers in this assay, from the lowest: compounds 3, 2, 4 and 1 (each within the scatter of the next).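

Placing 5-methyl-1,3,4-thiadiazol-2-yl in place of 3-methyl-1,2-oxazol-5-yl on a sulfonamide nitrogen gives, in this assay, a 1.2-fold higher number from compound 3 to compound 4 (0.09 log units; within the scatter) and so leaves the number where it was, even though the entering ring holds sulfur and one more hetero atom. Compared with the open-chain group on the same nitrogen, the thiadiazole gives a 1.1-fold higher number from compound 2 to compound 4 (0.03 log units; within the scatter) as well, so the two different five-membered rings and the group without a ring now all sit within the scatter of one another, and this position shows no order among its three groups. Nothing available beyond these numbers offers an explanation for this flat result.

On these data alone, all the groups compared here at this nitrogen are either aromatic five-membered rings or the one chain with two nitrogens, so it remains open whether a longer alkyl chain, or a simple amine, would move the number beyond the scatter. Also open, as far as these compounds go, is whether a carboxylic acid taking the place of the whole sulfonamide would change the number by more than these exchanges did.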